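Pentyl in Place of Hydrogen on Selenium, Two Cores

The source may hold more compounds than are shown below. What is called first, only, known or untested is meant among the compounds shown, and "the series" means these compounds.

Compound 2 `[SeH]c1nc(NCc2ccccc2)c2ccccc2n1` was tested in a functional assay on CCRF-CEM cells (Homo sapiens) for cytotoxicity, read by MTT assay, with a stated time of 72 h; a higher number here means that more compound is tolerated, a lower number that less compound is tolerated; compound 2 gives > 100000 nM, which is a limit of the assay and not a number. Compound 1 `CCCCC[Se]c1nc(NCc2ccccc2)c2ccccc2n1` carries pentyl in place of hydrogen on a selenium, and in this assay compound 1 gives > 100000 nM, again a limit. The step that the two limits leave unreadable from compound 2 to compound 1 can therefore not be sized. Compound 3 `Nc1nc([SeH])nc2ncccc12` rests on another core; the difference between the two cores is not broken down here. In this assay, among the measured compounds shown here, compound 3 gives 92100 nM, the only number among the three. Compound 4 `CCCCC[Se]c1nc(N)c2cccnc2n1` differs from compound 3 by pentyl in place of hydrogen on a selenium, the same change as that from compound 2 to compound 1. Since the limit of > 100000 nM in this assay, at which 2 of the 3 values shown sit, holds the earlier pair, no size can be carried over. Resting on compound 3 with 92100 nM, the step of a 1.2-fold higher number from compound 3 to compound 4 (0.08 log units; within the scatter) is expected to be small. Compound 4 is estimated at 110000 nM, between 40000 nM and 300000 nM.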

Compound 4, concentration lethal to 50% of the cells: 72600 nM
Estimate against measurement, compound 4: 1.5-fold (0.18 log units) above; the range from low to high includes it.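

In this assay, pentyl in place of hydrogen on a selenium amounts to a 1.3-fold lower number from compound 3 to compound 4 (0.10 log units; within the scatter), so on this core the change cannot be told apart from the usual scatter. The step on the core of compound 1 cannot be read, and the limits that hold it can be seen here: the limit of > 100000 nM in this assay, at which 2 of the 4 values shown sit. The pair on the core of compound 3 therefore stands alone, and it does not show whether the change has a similar size on both cores.

The compounds shown leave open whether a hexyl chain or a benzyl group in place of the hydrogen on a selenium would give a step beyond the scatter on either core. Going by these compounds, it also stays open whether any such group would bring the core of compound 1 off its limit.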